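The compounds below may be only part of what the source reports. "The series", "measured", "known", "first", "only" and "open" are said of these compounds alone.

Of the compounds shown here, three of one shared core have been tested so far, each carrying two hydroxyphenyl groups and one further small aromatic ring. Compound 1 `Oc1ccc(-c2cc(-c3ccsc3)cc(-c3ccccc3O)n2)cc1` carries a thiophen-3-yl group. In a functional assay on DU-145 cells (Homo sapiens) for cytotoxicity, read by CCK-8 assay (on this read-out lower numbers stand for stronger inhibition and higher numbers for weaker inhibition), compound 1 reaches only a limit of the assay, > 50000 nM. Compound 2 `Oc1ccc(-c2cc(-c3ccoc3)cc(-c3ccccc3O)n2)cc1` carries a furan-3-yl group in its place, and in this assay compound 2 gives 28000 nM. Among the compounds with values here, the only measured step, an at least 1.7-fold lower number from compound 1 to compound 2 (0.25 log units; that floor lies within the scatter), has a floor that lies within the usual scatter, so it shows no clear change.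

Compound 3 `Oc1ccccc1-c1cc(-c2cccnc2)cc(-c2ccccc2O)n1` carries a pyridin-3-yl group and two 2-hydroxyphenyl groups. In this assay compound 3 also reaches only a limit of the assay, > 50000 nM. Compound 3 thus stands at the limit of > 50000 nM in this assay, at which 2 of the 3 values shown sit, so its true potency is known only to be weak.

Compound 4 `Oc1ccc(-c2cc(-c3cccnc3)cc(-c3ccccc3O)n2)cc1` differs from compound 3 by 4-hydroxyphenyl in place of 2-hydroxyphenyl on an aromatic carbon. Within the data shown here, no measured step covers this exchange of one hydroxyphenyl for another. Compound 2, which likewise pairs a 4-hydroxyphenyl with a 2-hydroxyphenyl, gives 28000 nM, so weak inhibition is the expectation for this arrangement. Compound 4 is therefore expected to stay near the limit, with a step of a number no higher from compound 3 to compound 4 (the limit leaves the size open) that is not beyond the scatter. The estimate for compound 4 is 50000 nM, within a range from 25000 nM to 100000 nM.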

Compound 4, half-maximal inhibitory concentration: > 50000 nM
Compound 4 was reported as a limit; the forecaster's own chance of this, stated with the estimate: 60%; the middle value lies on the limit itself.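

With 4-hydroxyphenyl in place of 2-hydroxyphenyl next to the ring nitrogen, compound 4 still gives only a limit of the assay in this assay, so this exchange does not bring a number within the range of the assay, and the limit now holds most of the set: the limit of > 50000 nM in this assay, at which 3 of the 4 values shown sit.

The steps to compound 4 from compound 3 and from compound 1 join two limits and cannot be read. Within the data shown here, the one readable step puts pyridin-3-yl in place of furan-3-yl, an at least 1.7-fold higher number from compound 2 to compound 4 (0.25 log units; that floor lies within the scatter), and with that floor it shows no clear difference between these two rings.

Among these compounds, how far the two hydroxyphenyl arrangements really differ stays hidden, as compound 3 and compound 4 both rest on a limit, and compound 2 remains the only compound here with a true number. Also open, going by these compounds, is whether an amine or a carboxylic acid in place of the hydroxy group of 4-hydroxyphenyl, or a longer chain on the shared core, would give a value clearly inside the range of this assay.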